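The source may hold more compounds than are shown below. What is called first, only, known or untested is meant among the compounds shown, and "the series" means these compounds.

The measured compounds:

- compound 1, `O=C1NC(=S)/C(=C/c2ccc(Cl)cc2)S1`: 35.8%
- compound 2, `O=C1NC(=S)/C(=C/c2cccc(F)c2)S1`: 13.1%
- compound 3, `O=C1NC(=S)/C(=C/c2ccc(Cl)c(Cl)c2)S1`: 35.8%

All three share one core and differ only in the halogens on the aromatic ring. In a functional assay on NCI-H292 cells (Homo sapiens) for cytotoxicity, read by MTT assay, with a stated time of 72 h, tested at 5 ug/mL (a lower number here means less inhibition of growth, a higher number more inhibition of growth at the concentration tested), compound 1 gives 35.8%, and compound 3 gives 35.8%, so the two stand level within the scatter and together hold the highest of the three numbers. Compound 2 gives 13.1%, a number well below that of compound 1, beyond the scatter.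

Compound 4, `O=C1NC(=S)/C(=C/c2ccc(Cl)cc2Cl)S1`, has not yet been measured. It differs from compound 1 in one place: chloro in place of hydrogen on an aromatic carbon.

Among the compounds with values here, only one measured step bears on this change. A second chloro added to the ring gave no change at the digits printed from compound 1 to compound 3 (within the scatter). That step places the added chlorine at a different position on the ring than the one now in question, so it is only a partial guide, but it is the closest comparison available. With no sign that a second chloro moves the number, the expectation for compound 4 is a step of about a number 0.8 percentage points lower from compound 1 to compound 4 (within the scatter), which is to say none beyond the scatter. Compound 4 is therefore estimated at 35%, with a range from 20% to 50%.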

Compound 4, percent growth inhibition at one concentration: 29.3%
The estimate for compound 4 lay 5.7 percentage points above the measured number; low and high end bracket the measured number.
By their numbers in this assay, from the lowest: compound 2; then compounds 4, 1 and 3 (each within the scatter of the next).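

In this assay, a chloro placed ortho to a group of 8 heavy atoms and meta to a chloro group gives a reading of a number 6.5 percentage points lower from compound 1 to compound 4 (within the scatter), so this carbon of the ring accepts a second chloro with no shift beyond the scatter. Within the data shown here, until now, the only guide to a second chloro came from another carbon of the ring, with no change at the digits printed from compound 1 to compound 3 (within the scatter), and the new step shows the same outcome at a second site: within these compounds, adding this one chloro to compound 1 leaves the growth inhibition within the scatter at both places. Nothing at hand explains why the number holds, and the result by itself gives no reason for it.

Still open, as far as these compounds go, is whether a group of another kind at this same carbon, such as an amine, a carboxylic acid or a longer chain, would move the number beyond the scatter. Also open, from the compounds shown here alone, is how these compounds would compare across a range of concentrations, since each reading here comes from a single tested concentration.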